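A few compounds are considered here, and "the series" means these few. Any claim that something is new, unique, unknown or untested is made for them only; others in the source may bear on it.

Compound 1 `Cc1cn(C/C=C\CO)c(=O)[nH]c1=O`: > 1000000 nM (a limit)
Compound 2 `Cc1cn(C=C=CCO)c(=O)nc1N`: 620000 nM

In a functional assay on L1210 cells (Mus musculus) for inhibition (a higher number here means a weaker inhibitor, a lower number a stronger inhibitor), compound 1 stands at > 1000000 nM, which is a limit of the assay and not a number. Compound 3 `Cc1cn(CC#CCO)c(=O)[nH]c1=O` keeps the core of compound 1 and differs from it as follows: 3-hydroxyprop-1-yn-1-yl in place of 3-hydroxyprop-1-en-1-yl on a saturated chain carbon bound to an aromatic nitrogen. Within the data shown here, no measured pair shows what such a swap does, so no step beyond the usual scatter is expected in this assay, in either direction. The expected change is a number no higher from compound 1 to compound 3 (the limit leaves the size open). Compound 3 is estimated at 1000000 nM, with an expected range from 300000 nM to 3000000 nM.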

Compound 3, half-maximal inhibitory concentration: > 500000 nM
Compound 3 ended at the assay's limit (the forecaster's own chance of this, stated with the estimate: 80%); the middle value is on the limit's open side.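

No step can be read between compound 1 and compound 3, whose values in this assay are both limits and not numbers. On these data alone, whether 3-hydroxyprop-1-yn-1-yl in place of 3-hydroxyprop-1-en-1-yl changes inhibition at all, and by how much, stays open.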